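Triazole nitrogen substitution in the dichlorophenyl amide series

This account rests on a few compounds, and the source may have more. Where it says the series, first, only, none or still open, it means among the compounds named here.

Two compounds of the shared core carry numbers in an assay on NK92 cells for inhibition of interleukin-2 (Homo sapiens), read by AlphaScreen, with stated times of 30 min and 1 h; on this read-out lower numbers stand for stronger inhibition and higher numbers for weaker inhibition. Compound 1 `CCOC(CCn1c(Cc2nn(C)c(=O)c3ccccc23)nnc1SCC(=O)Nc1ccc(Cl)cc1Cl)OCC` reaches only the assay limit, giving > 30000 nM, which is a limit rather than a number; the limit of > 30000 nM in this assay, at which 1 of the 2 values shown sits, marks where it sits. For the measured compounds named here, compound 2 `Cn1nc(Cc2nnc(SCCCCCCCC(=O)Nc3ccc(Cl)cc3Cl)[nH]2)c2ccccc2c1=O` gives 450 nM, the only true number in the set, so it stands as the sole measured point of reference. Going by the values given here, compound 1 and compound 2 differ in more than one place, so their two values show no single step.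

Compound 3 `Cn1nc(Cc2nnc(SCCCCCCCC(=O)Nc3ccc(Cl)cc3Cl)n2CCC(=O)O)c2ccccc2c1=O` is compound 2 with 2-carboxyethyl in place of hydrogen on an aromatic nitrogen. Compound 1, which also bears a group on the ring nitrogen, sits at the limit, but its differing chain leaves the contribution of that substitution uncertain. The expected step from compound 2 to compound 3 is a loss of potency beyond the usual scatter, a 5.6-fold higher number from compound 2 to compound 3 (0.74 log units; beyond the scatter). Compound 3 is therefore estimated at 2500 nM, within a range of 400 nM to 15000 nM in this assay.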

Compound 3, half-maximal inhibitory concentration: 14300 nM
Compound 3: the middle estimate sits 5.7-fold (0.76 log units) below what was measured; measured number inside the range.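

For the compounds shown here, exchanging hydrogen for 2-carboxyethyl on an aromatic nitrogen gives in this assay a 32-fold higher number from compound 2 to compound 3 (1.50 log units; beyond the scatter) and provides the first single-place reading at this position. Compound 3 still returns a true number rather than a limit, so this substitution weakens the read-out without taking it to the assay limit. No measured property of the group accompanies the step, and the loss stays unexplained.

Going by these compounds, whether the loss follows the carboxylic acid or the added chain remains open: a methyl group, a propyl group, or the ethyl ester or primary amide of the same chain on this nitrogen would separate the two. The limit of compound 1 also stays unassigned, as that compound differs in its thioether chain as well.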